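The source may report more compounds than this note shows. Statements on the series, on what has been measured and on what is new or still open speak of the compounds shown alone.

In a functional assay on HCT-116 cells (Homo sapiens) for antiproliferative activity, read by MTT assay, with a stated time of 48 h (on this read-out higher numbers stand for weaker inhibition and lower numbers for stronger inhibition), compound 1 (`COc1ccc(-c2c(Nc3cccc(C(F)(F)F)c3)c3ccccc3oc2=O)cc1`) gives 55700 nM as its result. Compound 3 (`COc1ccc(-c2c(Nc3ccc(C)cc3)c3ccc(OC)cc3oc2=O)cc1`) gives 82400 nM in this assay and so lies within the usual scatter of compound 1, which means the two cannot be ranked against each other. For compound 2 (`COc1ccc(-c2c(Nc3cc(OC)c(OC)c(OC)c3)c3ccc(OC)cc3oc2=O)cc1`) the entry reads "not determined" (no result reported) and it adds nothing to the comparison. Among the measured compounds shown here, compound 1 therefore stands level with the only other number available.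

Compound 4 (`COc1ccc(-c2c(Nc3cccc(C(F)(F)F)c3)c3ccc(OC)cc3oc2=O)cc1`) differs from compound 1 at a single place: methoxy in place of hydrogen on an aromatic carbon and in plain words this is methoxy in place of hydrogen on an aromatic carbon. For the measured compounds named here, no two measured compounds differ at just one place, so the data hold no direct measure of this change. Going by the values given here, the only guide is that compound 3 at 82400 nM and compound 1 at 55700 nM sit close together, which gives no reason to expect a large shift. The expected change is a 1.1-fold higher number from compound 1 to compound 4 (0.03 log units; within the scatter) and this estimate stays within the usual scatter, with no firm direction. In this assay compound 4 is estimated at 60000 nM with 25000 nM to 110000 nM as the expected range of the result.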

Compound 4, half-maximal inhibitory concentration: 41200 nM
Estimate against measurement, compound 4: 1.5-fold (0.16 log units) above; the measured number falls inside the stated range.
By their numbers in this assay, from the lowest: compounds 4, 1 and 3 (each within the scatter of the next).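

In this assay, among the compounds shown here, placing methoxy in place of hydrogen on an aromatic carbon of the fused ring system gives a 1.4-fold lower number from compound 1 to compound 4 (0.13 log units; within the scatter), the first direct reading of this change at this position, and it shows that the position accepts methoxy with no shift that can be told apart from the scatter of repeated measurements. A second one-place comparison now exists, with methoxy present on both compounds, and 3-(trifluoromethyl)phenyl in place of 4-methylphenyl on the nitrogen gives a 2.0-fold lower number from compound 3 to compound 4 (0.30 log units; within the scatter), so neither of these two changes separates the compounds involved in this assay. Nothing measured here offers an explanation for either step.

Still open, on these data alone, is whether a different group on this same aromatic carbon, such as an amine, a carboxylic acid or a longer chain like butoxy, would move the number beyond the scatter. Also open, as far as these compounds go, is whether methoxy would behave the same way on the other carbons of that ring, or alongside other groups on the nitrogen.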